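Swapping a Saturated Ring for a Pyridine at the Chain End

The source may hold more compounds than are shown below. What is called first, only, known or untested is meant among the compounds shown, and "the series" means these compounds.

Measured so far:
compound 1 `c1ccc(CN(CCCCN(C[C@H]2Cc3ccccc3CN2)[C@H]2CCCc3cccnc32)Cc2ccccn2)nc1` gives > 30000 nM
compound 2 `c1ccc2c(c1)CN[C@@H](CN(CCCCNCC1CCOCC1)[C@H]1CCCc3cccnc31)C2` gives > 30000 nM
compound 3 `c1ccc2c(c1)CN[C@@H](CN(Cc1ccc(CNC3CCOCC3)cc1)[C@H]1CCCc3cccnc31)C2` gives > 30000 nM

All three values come from a functional assay on cells for agonist activity at C-X-C chemokine receptor type 4 (Homo sapiens), read by fluorescence and calcium flux, with a stated time of 90 s; on this read-out lower numbers stand for an effect already at smaller amounts and higher numbers for an effect only at larger amounts of compound. None of them is a true number. For compound 1 the result > 30000 nM is a limit of the assay. For compound 2 the result > 30000 nM is likewise only a limit. For compound 3 the result > 30000 nM is also a limit. For the measured compounds named here, compound 2 therefore stands exactly where its two neighbours stand, and the shared picture is the limit of > 30000 nM in this assay, at which 3 of the 3 values shown sit, so no ordering among the three can be drawn, and no step between them can be measured.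

Compound 4 `C(=C/CN(C[C@H]1Cc2ccccc2CN1)[C@H]1CCCc2cccnc21)\CNCc1ccccn1` has not yet been tested in this assay. It differs from compound 2 in one place: a group of 11 heavy atoms (9 carbon, 2 nitrogen; one six-membered aromatic ring with 1 hetero atom) in place of a group of 11 heavy atoms (9 carbon, 1 nitrogen, 1 oxygen; one six-membered non-aromatic ring with 1 hetero atom), on a saturated chain carbon bound to an amine nitrogen.

Going by the values given here, no measured step exists for this kind of change, and every value at hand is a limit, so there is nothing to anchor a direction. The expectation for the step from compound 2 to compound 4 in this assay is therefore a number no higher from compound 2 to compound 4 (the limit leaves the size open), which means no move beyond the scatter, with a real chance that the assay once more reports only a limit. On that basis compound 4 is estimated at 30000 nM, within a range from 8000 nM to 100000 nM.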

Compound 4, half-maximal effective concentration: > 30000 nM
Compound 4 was reported as a limit; the forecaster's own chance of this, stated with the estimate: 70%; the middle value sits exactly at the limit.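

Compound 2 and compound 4 are both reported only as limits, so no step can be read between them, and the picture stays as it was: the limit of > 30000 nM in this assay, at which 4 of the 4 values shown sit. The compounds shown leave open whether swapping the saturated ring for the aromatic one changes the effect in this assay at all, and what true number any of them would give.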